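Deoxy analogue of compound 2: working notes

The source may report more compounds than this note shows. Statements on the series, on what has been measured and on what is new or still open speak of the compounds shown alone.

Measured in a functional assay on A2780 cells (Homo sapiens) for cytotoxicity, read by MTT assay, with a stated time of 24 h; a lower number here means a stronger inhibitor, a higher number a weaker inhibitor:
- Compound 1 `CCCCC[C@@H](C[C@H](O)C[C@@H]1CC=CC(=O)O1)OC`: 35400 nM
- Compound 2 `CCCCC[C@@H](C[C@@H](O)C[C@@H]1CC=CC(=O)O1)OC`: 49400 nM

Within the data shown here, compound 2 stands level with compound 1, and that pair gives the only measured step, a 1.4-fold higher number from compound 1 to compound 2 (0.14 log units; within the scatter). It reflects (the fact that compounds 1 and 2 differ only in the configuration as drawn), so it bears only indirectly on the next change. Compound 3 `CCCCC[C@@H](CCC[C@@H]1CC=CC(=O)O1)OC` has hydrogen in place of hydroxy on a saturated chain carbon bound to two saturated chain carbons. No removal of the hydroxy has been measured, so no shift beyond the scatter is expected in this assay, in either direction, and the range stays wide. The expected step is a 1.1-fold lower number from compound 2 to compound 3 (0.04 log units; within the scatter). For compound 3 the estimated value is 45000 nM, with an expected range of 18000 nM to 110000 nM.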

Compound 3, half-maximal inhibitory concentration: 14900 nM
Estimate against measurement, compound 3: 3.0-fold (0.48 log units) above, and the stated range ends above it.
By their numbers in this assay, from the lowest: compound 3; then compounds 1 and 2 (each within the scatter of the next).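

In this assay, hydrogen in place of hydroxy on this saturated chain carbon gives a 3.3-fold lower number from compound 2 to compound 3 (0.52 log units; beyond the scatter), and likewise a 2.4-fold lower number from compound 1 to compound 3 (0.38 log units; beyond the scatter). The hydroxy is therefore not needed at this carbon for cytotoxicity in this series, and its removal lowers the number beyond the scatter from either hydroxy compound. Both steps point the same way, and their starting compounds are related in one respect only: the fact that compounds 1 and 2 differ only in the configuration as drawn.

Still open, from the compounds shown here alone, is how a fluorine, an amine or a carbonyl on this carbon would read. Going by these compounds, whether the same change holds with a longer chain is also open.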